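The source may hold more compounds than are shown below. What is called first, only, known or untested is meant among the compounds shown, and "the series" means these compounds.

Compound 1 `O=C(Nc1nc(-c2ccccc2)nc2c1nnn2Cc1ccccc1)C1CCCCC1` is the reference point of this set. In an assay (strain Wistar) for displacement of a labelled ligand from adenosine receptor A1 (Rattus norvegicus), read by scintillation counting (on this read-out lower numbers stand for stronger inhibition and higher numbers for weaker inhibition), compound 1 gives 12 nM, the second highest of the three numbers in hand. Compound 2 `O=C(Nc1nc(-c2ccccc2)nc2c1nnn2Cc1ccccc1)c1ccoc1` gives 10 nM, and the step of a 1.2-fold lower number from compound 1 to compound 2 (0.08 log units; within the scatter) lies within the scatter. Compound 3 `Cc1ccc(C(=O)Nc2nc(-c3ccccc3)nc3c2nnn3Cc2ccccc2)cc1` gives 709 nM; the step of a 59-fold higher number from compound 1 to compound 3 (1.77 log units; beyond the scatter) is large, as is a 71-fold higher number from compound 2 to compound 3 (1.85 log units; beyond the scatter). Compound 4 `O=C(Nc1nc(-c2ccccc2)nc2c1nnn2Cc1ccccc1)C1CCCC1` differs from compound 1 by cyclopentyl in place of cyclohexyl on a carbonyl carbon. Among the compounds with values here, no measured step bears directly on this change: the two steps from compound 1 swap the cyclohexyl for aromatic groups, one within the scatter and one large. For compound 4 the step of a 1.3-fold higher number from compound 1 to compound 4 (0.12 log units; within the scatter) is therefore expected to stay within the scatter. Compound 4 is estimated at 16 nM, in the range 6 nM to 45 nM.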

Compound 4, inhibition constant: 2.5 nM
Beside the measured number, compound 4's estimate is 6.4-fold (0.81 log units) above it; the whole stated range lies above it.
By their numbers in this assay, from the lowest: compound 4; then compounds 2 and 1 (each within the scatter of the next); then compound 3.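

At this position on a carbonyl carbon, the five-membered ring separates from the six-membered one, with a 4.8-fold lower number from compound 1 to compound 4 (0.68 log units; beyond the scatter) in this assay, whereas furan-3-yl in place of cyclohexyl stayed within the scatter. Cyclopentyl also separates from furan-3-yl, with a 4.0-fold lower number from compound 2 to compound 4 (0.60 log units; beyond the scatter), and the distance from the 4-methylphenyl amide grows, with a 280-fold lower number from compound 3 to compound 4 (2.45 log units; beyond the scatter). No evidence in hand accounts for these steps. Open, on these data alone, is whether cyclobutyl, cyclopropyl or an open chain such as isobutyl would give a lower or a higher number. Also open, as far as these compounds go, is how an amine or hydroxyl on the cyclopentyl ring would read.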